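Branching the alkyl on a cyanoguanidine series

The source may hold more compounds than are shown below. What is called first, only, known or untested is meant among the compounds shown, and "the series" means these compounds.

Measured so far:
compound 1, `N#CNC(=N)Nc1cccnc1` — 50 mg/kg
compound 2, `CCC/N=C(\NC#N)Nc1cccnc1` — 20 mg/kg
compound 3, `CC(C)(C)C/N=C(/NC#N)Nc1cccnc1` — 2.5 mg/kg

In a functional assay on the whole organism (blood, strain Wistar-Okamoto) with Rattus norvegicus as the target, with a stated time of 5 days (a lower number here means that less compound is needed, a higher number that more compound is needed for the effect), compound 2 stands second highest of the three numbers. Compound 1 gives 50 mg/kg, a higher number beyond the scatter, while compound 3 gives 2.5 mg/kg, a lower number well beyond the scatter. Compound 4, `CCC(C)/N=C(\NC#N)Nc1cccnc1`, has not yet been measured. It differs from compound 2 by methyl in place of hydrogen on a saturated chain carbon bound to a double-bonded nitrogen and a saturated chain carbon. For the measured compounds named here, since compound 3, the only compound bearing a branched chain, gives the lowest number, the step of a 2.0-fold lower number from compound 2 to compound 4 (0.30 log units; within the scatter) is expected to run toward a lower number, beyond the scatter though smaller than the gap to compound 3. Compound 4 is therefore estimated at 10 mg/kg, within a range from 4 mg/kg to 25 mg/kg.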

Compound 4, minimum effective dose: 20 mg/kg
Compound 4: the middle estimate sits 2.0-fold (0.30 log units) below what was measured, within the range that was stated.
By their numbers in this assay, from the lowest: compound 3; then compounds 2 and 4 (each within the scatter of the next); then compound 1.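

In this assay, methyl in place of hydrogen on a saturated chain carbon bound to a double-bonded nitrogen and a saturated chain carbon gives no change at the digits printed from compound 2 to compound 4 (within the scatter). For the compounds shown here, this is the first direct reading of a single change, and at this place propyl to sec-butyl leaves the minimum effective dose level. No measurement at hand accounts for this result. Going by these compounds, what a larger group at this carbon, such as ethyl or a cyclohexyl ring, would do remains open. So does the effect of a longer straight chain, such as hexyl.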